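Aryl Swap at the Saturated Ring Carbon: Compound 4

A few compounds are considered here, and "the series" means these few. Any claim that something is new, unique, unknown or untested is made for them only; others in the source may bear on it.

Compound 1 `CCOC(=O)C12C(=O)OCC=C1COC2c1ccccc1`: in a functional assay on A549 cells (Homo sapiens) for cytotoxicity, read by MTT assay (a lower number here means a stronger inhibitor, a higher number a weaker inhibitor), compound 1 gives > 1000000 nM, a limit of the assay.
Compound 2 `CCOC(=O)C12C(=O)OCC=C1COC2c1ccc(C(C)(C)C)cc1`: in this assay compound 2 gives > 1000000 nM, likewise a limit.
Compound 3 `CCOC(=O)C12C(=O)OCC=C1COC2c1cc(OC)cc(OC)c1`: in this assay compound 3 gives > 1000000 nM, likewise a limit.

Compound 1 stands only at a limit in this assay, as do the two further values, all three sitting at the limit of > 1000000 nM in this assay, at which 3 of the 3 values shown sit. The step that the two limits leave unreadable from compound 1 to compound 2 is therefore of unreadable size. Compound 4 `CCOC(=O)C12C(=O)OCC=C1COC2c1ccccn1` differs from compound 1 by pyridin-2-yl in place of phenyl on a saturated ring carbon. Among the measured steps, only the one between compound 1 and compound 2 touches the group on this saturated ring carbon, and its size is hidden by the two limits; no measured step involves a ring nitrogen. With nothing readable, the step of a number no higher from compound 1 to compound 4 (the limit leaves the size open) is expected to be none beyond the scatter. Compound 4 is accordingly estimated at 1000000 nM, within 300000 nM to 3000000 nM, most likely reported again only as a limit.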

Compound 4, half-maximal inhibitory concentration: > 1000000 nM
Compound 4 was reported as a limit; the forecaster's own chance of this, stated with the estimate: 85%; the middle value lies on the limit itself.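

No step can be read between compound 1 and compound 4, as both stand only at a limit: the limit of > 1000000 nM in this assay, at which 4 of the 4 values shown sit. The compounds shown leave open whether any change to the shared core gives a measurable value in this assay.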